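The source may hold more compounds than are shown below. What is called first, only, known or untested is meant among the compounds shown, and "the series" means these compounds.

Measured compounds:
compound 1, `Cc1cc(-c2cccc(O)c2)c2ncc(CSCCc3ccccc3)n2c1`: 20 ug/mL
compound 2, `Cc1cc(-c2ccccc2)cn2c(CSCCc3ccccc3)cnc12`: 20 ug/mL

Both were tested in an ADME assay on HEL cells (Homo sapiens) for cytotoxicity, with a stated time of 3 days; on this read-out higher numbers stand for lower toxicity in this test and lower numbers for higher toxicity in this test. Compound 1 gives 20 ug/mL in this assay, and compound 2 gives 20 ug/mL. The two readings are level at the digits shown, so they lie within the scatter of this kind of test, and nothing can be said about an order between them. Compound 1 therefore stands exactly where compound 2 stands on the numbers shown, with no other measured neighbour.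

The next compound, compound 3 `Cc1cc(-c2cccc([N+](=O)[O-])c2)c2ncc(CSCCc3ccccc3)n2c1`, has not yet been measured. It differs from compound 1 in one place: nitro in place of hydroxy on an aromatic carbon. Cut one bond further out, this reads 3-hydroxyphenyl to 3-nitrophenyl. Among the compounds with values here, no measured pair shows what such a swap does in this assay, so there is no counted step to lean on. Compound 3 is expected to stay close to compound 1, with an expected step of no change at the digits printed from compound 1 to compound 3 (within the scatter), no larger than the scatter. The estimate for compound 3 is 20 ug/mL, in a range from 8 ug/mL to 50 ug/mL.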

Compound 3, minimum cytotoxic concentration: 100 ug/mL
The estimate for compound 3 lay 5.0-fold (0.70 log units) below the measured number, outside the stated range (above it).
By their numbers in this assay, from the lowest: compounds 1 and 2 (each within the scatter of the next); then compound 3.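

In this assay the change from 3-hydroxyphenyl to 3-nitrophenyl gives a 5.0-fold higher number from compound 1 to compound 3 (0.70 log units; beyond the scatter) and so moves the number beyond the scatter, towards lower toxicity in this test. Within the data shown here, this is the first sign that the group on this aromatic carbon can shift the read-out, as the earlier compounds offered no step that differed in one place. No measurement available here explains why the number rises with this swap.

A single step cannot separate the effect of losing the hydroxy group from that of gaining the nitro group, and it cannot show whether other groups on the same carbon would raise the number too. An amine, a carboxylic acid or a methoxy group at this spot would help to settle this, and the same swap on a compound with a different side chain would show whether the step carries over beyond the core of compound 1.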